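Benzothiophene Carbonyl Replaces Dichlorophenyl in Cytotoxicity Series

A few compounds are considered here, and "the series" means these few. Any claim that something is new, unique, unknown or untested is made for them only; others in the source may bear on it.

Compound 1 `O=C1c2ccccc2C(=O)N1CCOC(=S)N(C(=O)c1c(F)cccc1F)c1ccc(Cl)cc1`: 39000 nM
Compound 2 `O=C1c2ccccc2C(=O)N1CCOC(=S)N(C(=O)c1c(Cl)cccc1Cl)c1ccc(Cl)cc1`: 20000 nM

In an ADME assay on MT4 cells (Homo sapiens) for cytotoxicity, read by MTT assay (on this read-out lower numbers stand for higher toxicity in this test and higher numbers for lower toxicity in this test), compound 2 shows the lowest of the two numbers; its nearest neighbour is compound 1, separated by a 2.0-fold lower number from compound 1 to compound 2 (0.29 log units; within the scatter). Compound 3 `O=C1c2ccccc2C(=O)N1CCOC(=S)N(C(=O)c1cc2ccccc2s1)c1ccc(Cl)cc1` carries the change (1-benzothiophen-2-yl in place of 2,6-dichlorophenyl on a carbonyl carbon). For the measured compounds named here, the single measured step that bears on this position, a 2.0-fold lower number from compound 1 to compound 2 (0.29 log units; within the scatter), swapped halogens on one ring and stayed within the scatter; no measured step covers a ring system entering at the carbonyl carbon. Without such a precedent, no shift beyond the scatter is expected. For compound 3 a value of 20000 nM is estimated, with a range from 7000 nM to 55000 nM. The implied step, no change at the digits printed from compound 2 to compound 3 (within the scatter), is expected to remain within the scatter.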

Compound 3, half-maximal cytotoxic concentration: 56000 nM
The estimate for compound 3 lay 2.8-fold (0.45 log units) below the measured number; measured number above the stated range.
By their numbers in this assay, from the lowest: compounds 2, 1 and 3 (each within the scatter of the next, the first and the last beyond it).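

In this assay, this carbonyl carbon proves able to carry a change that moves the number beyond the scatter: with 1-benzothiophen-2-yl in place of 2,6-dichlorophenyl, the result is a 2.8-fold higher number from compound 2 to compound 3 (0.45 log units; beyond the scatter). Against 2,6-difluorophenyl, the same group gives a 1.4-fold higher number from compound 1 to compound 3 (0.16 log units; within the scatter), so the shift stands only against the dichlorinated compound. Nothing available explains this step. The compounds shown leave open how an unsubstituted phenyl or a piperidine would read on this carbonyl carbon. They also leave open whether the sulfur matters, which a 1-benzofuran-2-yl group would test.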